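One ring swapped on a shared core

A few compounds are considered here, and "the series" means these few. Any claim that something is new, unique, unknown or untested is made for them only; others in the source may bear on it.

Compound 1 (`O=C([C@H](O)CS(=O)(=O)c1ccc2cc(Cl)ccc2c1)N1CCC(N2CCOC2=O)CC1`): 1.75
Compound 2 (`O=C([C@H](O)CS(=O)(=O)c1ccc2cc(Cl)ccc2c1)N1CCC(N2CCCOC2=O)CC1`): 1.67
Compound 3 (`O=C([C@H](O)CS(=O)(=O)c1ccc2cc(Cl)ccc2c1)N1CCC(N2NCCCC2=O)CC1`): 1.85

These three compounds were measured in a physicochemical assay for lipophilicity, measured as octanol-water partition, at pH 7.4 (a lower number here means a more polar compound, a higher number a more lipophilic compound), and differ only in the ring carried on a saturated ring carbon. Their values stand close together, and compound 3 is level with the others: the steps are a number 0.10 log units higher from compound 1 to compound 3 (within the scatter) and a number 0.18 log units higher from compound 2 to compound 3 (within the scatter) and, for the remaining pair, a number 0.08 log units lower from compound 1 to compound 2 (within the scatter) as well.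

Compound 4 (`O=C([C@H](O)CS(=O)(=O)c1ccc2cc(Cl)ccc2c1)N1CCC(N2CCCCCC2=O)CC1`) changes that same place again (a group of 8 heavy atoms (6 carbon, 1 nitrogen, 1 oxygen; one seven-membered non-aromatic ring with 1 hetero atom) in place of a group of 7 heavy atoms (4 carbon, 2 nitrogen, 1 oxygen; one six-membered non-aromatic ring with 2 hetero atoms), on a saturated ring carbon). The entering group is 2-oxoazepan-1-yl. Going by the values given here, the measured ring swaps are the only guide, and the largest of them is a number 0.18 log units higher from compound 2 to compound 3 (within the scatter) but none of them reaches a group with this much carbon. A modest rise in this assay beyond that largest step is therefore expected, although its size is uncertain. The estimated change is a number 0.40 log units higher from compound 3 to compound 4 (beyond the scatter) and could prove smaller. For compound 4 the estimated value is 2.25 (expected range 1.85 to 2.65).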

Compound 4, distribution coefficient: 2.52
Beside the measured number, compound 4's estimate is 0.27 log units below it, and the stated range covers the measured number.
By their numbers in this assay, from the lowest: compounds 2, 1 and 3 (each within the scatter of the next); then compound 4.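

In this assay, going by these compounds alone, the earlier ring swaps at this position all stayed within the scatter, and 2-oxoazepan-1-yl is the first group here to go beyond it: a number 0.67 log units higher from compound 3 to compound 4 (beyond the scatter), a number 0.85 log units higher from compound 2 to compound 4 (beyond the scatter) and a number 0.77 log units higher from compound 1 to compound 4 (beyond the scatter). The change from compound 3 to compound 4 alters the ring size, the carbon count and the number of hydrogen-bond donors all at once, so these compounds cannot show which of these differences matters. Nothing measured here explains the rise.

On these data alone, what 2-oxopiperidin-1-yl, a six-membered ring with a single hetero atom, would give at this place remains open, as does the result for a ring carrying an amine or a carboxylic acid. It is also unknown whether a step of this size would hold on a different core.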